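A few compounds are considered here, and "the series" means these few. Any claim that something is new, unique, unknown or untested is made for them only; others in the source may bear on it.

Three measured compounds share one core and differ only in the outer aromatic ring. Compound 1 `Cc1ccc(CN2CCC(CCN(Cc3ccc(-c4ccc(F)cc4)cc3)C(=O)NC(C)C)CC2)cc1` gives 383 nM in an in vitro functional assay on HEK293 cells for antagonist activity at melanin-concentrating hormone receptor 1 (Homo sapiens), read by GTPgammaS binding, with a stated time of 45 min; on this read-out lower numbers stand for stronger inhibition and higher numbers for weaker inhibition. Compound 2 `Cc1ccc(CN2CCC(CCN(Cc3ccc(-c4cccc(C#N)c4)cc3)C(=O)NC(C)C)CC2)cc1` gives 1010 nM in this assay. Compound 3 `Cc1ccc(CN2CCC(CCN(Cc3ccc(-c4ccccc4)cc3)C(=O)NC(C)C)CC2)cc1` gives 220 nM in this assay, the lowest number of the three, though one of the two steps toward it is only a 1.7-fold lower number from compound 1 to compound 3 (0.24 log units; within the scatter), whereas the other is a 4.6-fold lower number from compound 2 to compound 3 (0.66 log units; beyond the scatter). Compound 4 `CCC(CO)(CO)NC(=O)N(CCC1CCN(Cc2ccc(C)cc2)CC1)Cc1ccc(-c2ccccc2)cc1` is not yet measured. It differs from compound 3 at a different place: 1,1-bis(hydroxymethyl)propyl in place of isopropyl on an amide-type nitrogen. The measured steps, a 2.6-fold higher number from compound 1 to compound 2 (0.42 log units; beyond the scatter) and a 4.6-fold lower number from compound 2 to compound 3 (0.66 log units; beyond the scatter), all concern the outer ring and say nothing about the urea side. There is no measured guide for this change, so the expectation for compound 4 rests on compound 3 alone, with a wide range. Compound 4 is estimated at 450 nM, between 120 nM and 1700 nM. That estimate corresponds to an expected step of a 2.0-fold higher number from compound 3 to compound 4 (0.31 log units; beyond the scatter) in this assay.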

Compound 4, antagonist equilibrium constant: 147 nM
For compound 4 the middle estimate is 3.1-fold (0.49 log units) above the measured one, within the range that was stated.
By their numbers in this assay, from the lowest: compounds 4, 3 and 1 (each within the scatter of the next, the first and the last beyond it); then compound 2.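

Replacing isopropyl with 1,1-bis(hydroxymethyl)propyl on the amide-type nitrogen gives a 1.5-fold lower number from compound 3 to compound 4 (0.18 log units; within the scatter) in this assay and so leaves the result inside the usual scatter. Among these compounds, this is the first view of this side of the molecule, and it shows that the position accepts a group of 7 heavy atoms with 2 hydrogen-bond donors in place of one of 3 heavy atoms with none, without a change that can be told from scatter. The compounds shown offer no explanation for this outcome.

On these data alone, whether the two hydroxymethyl arms matter together or singly stays open, and a single 2-hydroxyethyl group, a tert-butyl group or a carboxylic acid at this nitrogen would help to separate those cases. As far as these compounds go, it is also open whether this change would read the same with a 4-fluorophenyl or 3-cyanophenyl outer ring.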